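Halogen-to-Trifluoromethyl Swap on a Diaryl Ether Cytotoxicity Series

The source may hold more compounds than are shown below. What is called first, only, known or untested is meant among the compounds shown, and "the series" means these compounds.

Measured compounds:
- compound 1, `N#Cc1ccc(Nc2nccc(Oc3ccc(-c4ccc(C#N)cc4)c(F)c3)n2)cc1`: > 307000 nM
- compound 2, `N#Cc1ccc(Nc2nccc(Oc3ccc(-c4ccc(C#N)c(Cl)c4)cc3Cl)n2)cc1`: 14900 nM
- compound 3, `N#Cc1ccc(Nc2nccc(Oc3ccc(-c4ccc(C#N)cc4)c(Cl)c3)n2)cc1`: 31100 nM

The three compounds share one core and differ only in the substituents on the two outer aromatic rings. In a functional assay on MT4 cells (Homo sapiens) for cytotoxicity, read by MTT assay, with a stated time of 5 days (on this read-out higher numbers stand for lower toxicity in this test and lower numbers for higher toxicity in this test), compound 1 gives > 307000 nM, which is a limit of the assay rather than a number (the limit of > 307000 nM in this assay, at which 1 of the 3 values shown sits). Compound 3 gives 31100 nM in this assay, the highest of the two actual numbers; its nearest neighbour is compound 2, which gives 14900 nM, a gap that lies beyond the scatter.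

Compound 4, `N#Cc1ccc(Nc2nccc(Oc3ccc(-c4ccc(C#N)cc4)c(C(F)(F)F)c3)n2)cc1`, is not yet measured. It differs from compound 3 by trifluoromethyl in place of chloro on an aromatic carbon.

Going by the values given here, only one measured step touches the same position: an at least 9.8-fold lower number from compound 1 to compound 3 (0.99 log units; beyond the scatter). That step shows the substituent at this carbon can move the number well beyond the scatter. For the trifluoromethyl group no measured neighbour exists, so the direction is open; compound 4 is estimated to land close to compound 3 or somewhat lower, a 1.6-fold lower number from compound 3 to compound 4 (0.19 log units; within the scatter). The estimate for compound 4 in this assay is 20000 nM, with a range from 6000 nM to 60000 nM.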

Compound 4, half-maximal cytotoxic concentration: > 273000 nM
Compound 4 was reported as a limit; the forecaster's own chance of this, stated with the estimate: 15%; at least 13-fold (1.13 log units) between middle value and limit.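

In this assay, trifluoromethyl in place of chloro on this aromatic carbon, ortho to the 4-cyanophenyl group, gives an at least 8.7-fold higher number from compound 3 to compound 4 (0.94 log units; beyond the scatter), so the position can respond strongly in the direction of lower toxicity in this test, which the earlier compounds had not shown for a larger group. Compound 4 is reported only as a limit of the assay, not as a number: the limit of > 273000 nM in this assay, at which 1 of the 4 values shown sits. Compound 1, with fluoro on the same carbon, is likewise only a limit, so the step between these two compounds cannot be read, and of the three groups compared here, only chloro gives an actual number: the limit of > 307000 nM in this assay, at which 1 of the 4 values shown sits.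

Compound 3, with chloro on this carbon, gives 31100 nM. The compounds shown leave open whether bromo or methyl on this carbon would give an actual number or another limit. They also leave open how chloro or trifluoromethyl here would behave alongside further changes, since compound 2, at 14900 nM, differs from compound 3 in more than one place.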